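Adding a Third Methoxy to a Pyrazoline Sulfonamide Series

The compounds below may be only part of what the source reports. "The series", "measured", "known", "first", "only" and "open" are said of these compounds alone.

Of the compounds shown here, three share one core and have been tested in a functional assay on BT-549 cells (Homo sapiens) for antiproliferative activity, with a stated time of 48 h; a lower number here means a stronger inhibitor of growth, a higher number a weaker inhibitor of growth. Compound 1 `Cc1cc(O)c(C2=NN(c3ccc(S(N)(=O)=O)cc3)C(c3ccccc3O)C2)cc1Cl` gives 2470 nM, compound 2 `Cc1cc(O)c(C2=NN(c3ccc(S(N)(=O)=O)cc3)C(c3ccccc3Cl)C2)cc1Cl` gives 2160 nM, and compound 3 `COc1ccc(C2CC(c3cc(Cl)c(C)cc3O)=NN2c2ccc(S(N)(=O)=O)cc2)cc1OC` gives 3030 nM, the highest of the three numbers, though its gaps to the others are small: a 1.2-fold higher number from compound 1 to compound 3 (0.09 log units; within the scatter) and a 1.4-fold higher number from compound 2 to compound 3 (0.15 log units; within the scatter). The step of a 1.1-fold lower number from compound 1 to compound 2 (0.06 log units; within the scatter) is likewise small. Compound 4 `COc1ccc(C2CC(c3cc(Cl)c(C)cc3O)=NN2c2ccc(S(N)(=O)=O)cc2)c(OC)c1OC` differs from compound 3 by one change: methoxy in place of hydrogen on an aromatic carbon. For the measured compounds named here, no measured step tests a methoxy added to this ring; the two steps that touch the same part of the molecule, from compound 1 to compound 3 and from compound 2 to compound 3, swapped whole aryl groups and stayed within the scatter. Compound 4 is therefore expected to sit close to compound 3, with no step beyond the scatter, and the estimated step is a 1.0-fold lower number from compound 3 to compound 4 (0.00 log units; within the scatter). The estimate for compound 4 in this assay is 3000 nM, with a range from 1500 nM to 6500 nM.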

Compound 4, concentration for 50% growth inhibition: 2600 nM
Compound 4: middle estimate off by 1.2-fold (0.06 log units), on the high side, within the range that was stated.
By their numbers in this assay, from the lowest: compounds 2, 1, 4 and 3 (each within the scatter of the next).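

In this assay, for the compounds shown here, the step from the 3,4-dimethoxyphenyl to the 2,3,4-trimethoxyphenyl group gives a 1.2-fold lower number from compound 3 to compound 4 (0.07 log units; within the scatter) and is the first direct test of adding a group to this ring: a methoxy in place of hydrogen, on the aromatic carbon ortho to a large group, leaves the growth-inhibition number within the scatter. The trimethoxyphenyl group also stays within the scatter of the 2-chlorophenyl group, with a 1.2-fold higher number from compound 2 to compound 4 (0.08 log units; within the scatter) as the step, and of the 2-hydroxyphenyl group, with a 1.1-fold higher number from compound 1 to compound 4 (0.02 log units; within the scatter) as the step. Nothing measured here offers an explanation for this result. Going by these compounds, whether an amine or a carboxylic acid at this same carbon would move the number beyond the scatter remains open. So does the effect of an ethoxy or a longer chain there.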